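This account rests on a few compounds, and the source may have more. Where it says the series, first, only, none or still open, it means among the compounds named here.

Compound 2, `CCOC(=O)CCCCCOc1cccc(CN(C(=O)c2ccc(-c3ccc4c(c3)OCCO4)cc2)C(C)C)c1`, stands among two values that are both limits rather than numbers. In an ADME assay on HEK293 cells (Homo sapiens) for cytotoxicity, read by CellTiter-Glo and resazurin assay, with a stated time of 72 h (on this read-out lower numbers stand for an effect already at smaller amounts and higher numbers for an effect only at larger amounts of compound), compound 2 gives > 24400 nM, a limit of the assay. Compound 1, `CCOC(=O)CCCCCOc1cccc(CN(C(=O)c2ccc(-c3ccc4ccccc4c3)cc2)C(C)C)c1`, shows the same kind of result. In this assay compound 1 gives > 26000 nM, again a limit. For the measured compounds named here, the one step measured so far, a step that the two limits leave unreadable from compound 1 to compound 2, therefore cannot be read for size; the two limits the limit of > 24400 nM in this assay, at which 1 of the 2 values shown sits, and the limit of > 26000 nM in this assay, at which 1 of the 2 values shown sits, tell only that neither compound reached a half-maximal effect within the range tested. Compound 3, `CCOC(=O)CCCCCOc1cccc(CN(C(=O)c2ccc(-c3cccc(Br)c3)cc2)C(C)C)c1`, is not yet measured. It departs from compound 2 by 3-bromophenyl in place of 2,3-dihydro-1,4-benzodioxin-6-yl on an aromatic carbon. Going by the values given here, no measured step bears directly on this change, and the single step recorded leaves both of its ends at a limit, so no shift beyond the scatter is expected in either direction. Compound 3 is therefore expected to return a limit as well, with an estimate of 25000 nM and a range from 10000 nM to 60000 nM in this assay. The expected step that the limit leaves unreadable from compound 2 to compound 3 is essentially none.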

Compound 3, half-maximal effective concentration: > 26000 nM
Compound 3 gave a limit, no number (the forecaster's own chance of this, stated with the estimate: 75%); middle value at least 1.0-fold (0.01 log units) from the limit.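

Compound 3 also ends at a limit in this assay, so neither its step from compound 2 nor its step from compound 1 can be read for size. The compounds shown leave open whether naphthalen-2-yl, 2,3-dihydro-1,4-benzodioxin-6-yl or 3-bromophenyl on the shared core makes any difference to the half-maximal effective concentration, as none yields a number.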